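Three Near-Identical Readings Before a Carboxylic Acid Tail

The compounds below may be only part of what the source reports. "The series", "measured", "known", "first", "only" and "open" are said of these compounds alone.

Compound 1 `Cc1ncc(-c2ccccc2)c(C(C)(C)C)n1` gives 22% in a functional assay on the whole organism for inhibition, with Rattus norvegicus as the target, with stated times of 1 h and 3.5 h, at a dose of 100 mg/kg by the oral route; on this read-out higher numbers stand for more inhibition at the one dose given (going by the name of the read-out) and lower numbers for less inhibition.
Compound 2 `CC(=O)N(C(C)=O)c1ncc(-c2ccccc2)c(C(C)(C)C)n1` gives 22% in this assay.
Compound 3 `CCOC(=O)Nc1ncc(-c2ccccc2)c(C(C)(C)C)n1` gives 24% in this assay.

All three share one core and differ only in the group on a single aromatic carbon. Compound 3 holds the highest of the three numbers, yet its nearest neighbour is compound 1 and its furthest is compound 2, and both gaps sit within the scatter, so no order among the three can be claimed.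

Compound 4 `CC(C)(C)c1nc(NC(=O)CCCC(=O)O)ncc1-c1ccccc1` keeps the (ethoxycarbonyl)amino pattern of compound 3 but alters its far end: 3-carboxypropyl in place of ethoxy on a carbonyl carbon. The group that leaves is ethoxy; the group that enters is 3-carboxypropyl, which brings a hydrogen-bond donor and a double bond outside aromatic rings.

Among the compounds with values here, no measured step swaps groups on a carbonyl carbon, so nothing bears on this change directly. The steps that touch the same side chain, a number 2 percentage points higher from compound 1 to compound 3 (within the scatter) and a number 2 percentage points higher from compound 2 to compound 3 (within the scatter), are both within the scatter, as is no change at the digits printed from compound 1 to compound 2 (within the scatter). The read-out has stayed flat through every change tried so far.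

The step of a number 1 percentage points lower from compound 3 to compound 4 (within the scatter) is therefore expected to be none beyond the scatter. Compound 4 is estimated at 23%, with a range from 8% to 38%.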

Compound 4, a percentage reported as inhibition, in the whole organism at one dose (the size of the read-out at that dose, not a potency): 5%
Estimate against measurement, compound 4: 18 percentage points above; measured number below the stated range.
By their numbers in this assay, from the lowest: compound 4; then compounds 1, 2 and 3 (each within the scatter of the next).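

Until this point, the changes on the aromatic carbon left the numbers in this assay flat, which gave no sign that this part of the molecule mattered. Within the data shown here, replacing ethoxy with 3-carboxypropyl on the carbonyl carbon gives a number 19 percentage points lower from compound 3 to compound 4 (beyond the scatter) and is the first step here to pass beyond the scatter, so the read-out does respond to the far end of this side chain, and the response is less inhibition at the one dose given. No measurement shown here accounts for this loss.

This single step changes both the size of the group and its end, so it cannot show which of the two matters: the enlarged group has a longer chain and also ends in a carboxylic acid. A plain propyl group, the methyl ester of the acid or a chain ending in an amine on the same carbonyl carbon would help separate these two possibilities, and a shorter or longer chain carrying the carboxylic acid would show whether the length of the chain affects the result.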